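Acetyl on the ring amine of compound 2

The compounds below may be only part of what the source reports. "The series", "measured", "known", "first", "only" and "open" are said of these compounds alone.

Measured in an ADME assay on a cell-free system (plasma, Sus scrofa) for metabolic stability, read by LC-MS, with a stated time of 1 h, tested at 10 uM; a higher number here means that more of the compound is left, a lower number that less of the compound is left:
compound 1 `CCCCCCCCCCCCCCCC(=O)N[C@@H](CCCCNC(C)=O)C(=O)N[C@@H](CCC(=O)C=[N+]=[N-])C(=O)OC(C)C`: 88%
compound 2 `CC(=O)NCCCC[C@H](NC(=O)[C@@H]1Cc2ccccc2CN1)C(=O)N[C@@H](CCC(=O)C=[N+]=[N-])C(=O)OC(C)C`: 62%
compound 3 `CC(=O)NCCCC[C@H](NC(=O)OC(C)(C)C)C(=O)N[C@@H](CCC(=O)C=[N+]=[N-])C(=O)OC(C)C`: 85%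

Compound 2 holds the lowest of the three numbers, while compound 1 and compound 3 lie within the scatter of each other. Compound 4 `CC(=O)NCCCC[C@H](NC(=O)[C@@H]1Cc2ccccc2CN1C(C)=O)C(=O)N[C@@H](CCC(=O)C=[N+]=[N-])C(=O)OC(C)C` is compound 2 with one change, acetyl in place of hydrogen on an amine nitrogen in a ring.

Among the compounds with values here, only one measured step bears on this: a number 23 percentage points higher from compound 2 to compound 3 (beyond the scatter). It is a modest step, and it replaces the whole group on the carbonyl carbon, so it is an indirect guide. Within the data shown here, compound 4 keeps the ring of compound 2, and no measured pair shows acetyl on this nitrogen. Neither compound 1 nor compound 3 has a ring amine with a hydrogen on it. A rise of similar or somewhat smaller size is therefore expected, and the estimated step is a number 18 percentage points higher from compound 2 to compound 4 (beyond the scatter) in this assay. For compound 4 the estimated value is 80%, with an expected range of 66% to 92%.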

Compound 4, percent of the compound remaining: 98%
The estimate for compound 4 lay 18 percentage points below the measured number, and the stated range ends below it.
By their numbers in this assay, from the lowest: compound 2; then compounds 3, 1 and 4 (each within the scatter of the next, the first and the last beyond it).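

In this assay, acetyl in place of hydrogen on an amine nitrogen in a ring gives a number 36 percentage points higher from compound 2 to compound 4 (beyond the scatter) and is a large step. Within the data shown here, this is the first direct reading at this nitrogen. The earlier step of a number 23 percentage points higher from compound 2 to compound 3 (beyond the scatter) replaced the whole group on the carbonyl carbon, whereas here the ring stays, so the low number of compound 2 does not depend on the presence of the ring alone and changes with the hydrogen on this nitrogen. Nothing measured on these compounds gives a reason for the step.

Open, from the compounds shown here alone, is whether the rise belongs to acetyl itself or would also come with a methyl, a propionyl or a methanesulfonyl group on the same nitrogen. Also open, going by these compounds, is whether an acetylated open-chain amine in place of the ring would behave like compound 4.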